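Chloro to butyl on the aryl of compound 2

The source may report more compounds than this note shows. Statements on the series, on what has been measured and on what is new or still open speak of the compounds shown alone.

Compound 2 `O=C1C2=C(C(=O)c3ncccc31)C1(CS2)NC(=O)N(c2ccc(Cl)cc2)C1=O` stands lowest of the three numbers in a functional assay on CCRF-SB cells (Homo sapiens) for antiproliferative activity, read by MTT assay, with a stated time of 96 h; on this read-out higher numbers stand for weaker inhibition and lower numbers for stronger inhibition: compound 2 gives 10 nM. Compound 3 `Cc1ccc(N2NC(=O)NC3(CSC4=C3C(=O)c3ncccc3C4=O)C2=O)cc1` gives 37 nM in this assay, and compound 1 `O=C1NNC(=O)C2(CSC3=C2C(=O)c2ncccc2C3=O)N1` gives 48 nM. Compound 4 `CCCCc1ccc(N2C(=O)NC3(CSC4=C3C(=O)c3ncccc3C4=O)C2=O)cc1` is the next compound in the series and is not yet measured in this assay. Its difference from compound 2 is butyl in place of chloro on an aromatic carbon.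

For the measured compounds named here, the only single-point step so far is a 1.3-fold lower number from compound 1 to compound 3 (0.11 log units; within the scatter), which concerns the nitrogen of the shared core rather than the aryl substituent. Going by the values given here, compound 2 and compound 3 differ in more than one place, so their values show only that compound 2 sits lower. Among the compounds with values here, no measured step touches the group on the aromatic carbon of the six-membered aromatic ring of carbon only, so nothing speaks for a large move in either direction. The expectation is therefore that compound 4 stays near compound 2, with a step of a 1.8-fold higher number from compound 2 to compound 4 (0.26 log units; within the scatter) that is not expected to exceed the scatter, and at most a modest drift upward. The estimate for compound 4 in this assay is 18 nM, expected between 7 nM and 45 nM.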

Compound 4, half-maximal inhibitory concentration: 190 nM
Compound 4: middle estimate off by 11-fold (1.02 log units), on the low side, outside the stated range (above it).
By their numbers in this assay, from the lowest: compound 2; then compounds 3 and 1 (each within the scatter of the next); then compound 4.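

Swapping chloro for butyl on an aromatic carbon, para to a large group, is the first single-point change at this place, and in this assay it gives a 19-fold higher number from compound 2 to compound 4 (1.28 log units; beyond the scatter). For the compounds shown here, the place is therefore sensitive: a change from 4-chlorophenyl to 4-butylphenyl, which brings in no ring, no hydrogen-bond donor or acceptor and no net charge, moves the number well beyond the scatter, whereas the only earlier single-point step, a 1.3-fold lower number from compound 1 to compound 3 (0.11 log units; within the scatter), lies at a different place and within the scatter. Nothing in the available data bears on why the number rises at this place.

With only chloro and butyl compared here, the step cannot separate the loss of chloro from the arrival of the chain, and it gives no trend with chain length. An ethyl or propyl chain on the same carbon would show whether the number climbs gradually with length, while an amine or a carboxylic acid there would show whether a group other than a plain carbon chain is tolerated.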